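Replacing an Anilide with a Propyl Ester: Expected Cytotoxicity

The compounds below may be only part of what the source reports. "The series", "measured", "known", "first", "only" and "open" are said of these compounds alone.

Measured so far in a toxicity assay on L02 cells (Homo sapiens) for cytotoxicity, read by MTT assay, with a stated time of 24 h; on this read-out lower numbers stand for higher toxicity in this test and higher numbers for lower toxicity in this test:
compound 1 `CCCCS(=O)(=O)Oc1ccc(/C=C/C(=O)OCC)cc1OC` gives 14400 nM;
compound 2 `CCCCOC(=O)/C=C/c1ccc(OS(=O)(=O)c2ccc(Cl)cc2)c(OC)c1` gives 14000 nM;
compound 3 `CCCCS(=O)(=O)Oc1ccc(/C=C/C(=O)Nc2ccccc2C)cc1OC` gives 56100 nM.

Compound 3 holds the highest number of the three, and its separation from both other compounds lies beyond the scatter; the nearest is compound 1. Among the compounds with values here, the one single-point step among the measured compounds is a 3.9-fold higher number from compound 1 to compound 3 (0.59 log units; beyond the scatter), which put an amide in place of an ester on the carbonyl carbon and raised the number.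

Compound 4 `CCCCS(=O)(=O)Oc1ccc(/C=C/C(=O)OCCC)cc1OC` differs from compound 3 at that same carbonyl carbon: propoxy in place of (2-methylphenyl)amino on a carbonyl carbon. This change essentially undoes the earlier one, with a propoxy rather than an ethoxy ester, so the step of a 3.9-fold higher number from compound 1 to compound 3 (0.59 log units; beyond the scatter) is the one that bears on it, read in reverse. A drop of roughly that size is therefore expected, landing near compound 1. Compound 4 is estimated at 16000 nM, with a range from 7000 nM to 40000 nM, meaning an expected step of a 3.5-fold lower number from compound 3 to compound 4 (0.54 log units; beyond the scatter).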

Compound 4, half-maximal cytotoxic concentration: 61800 nM
Estimate against measurement, compound 4: 3.9-fold (0.59 log units) below, outside the stated range (above it).
By their numbers in this assay, from the lowest: compounds 2 and 1 (each within the scatter of the next); then compounds 3 and 4 (each within the scatter of the next).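

In this assay, propoxy in place of (2-methylphenyl)amino on a carbonyl carbon gives a 1.1-fold higher number from compound 3 to compound 4 (0.04 log units; within the scatter), so this test does not tell these two groups apart, even though one carries a ring and the other does not. Within the esters, methyl in place of hydrogen on a saturated chain carbon, two bonds along the chain from an oxygen next to a carbonyl group, gives a 4.3-fold higher number from compound 1 to compound 4 (0.63 log units; beyond the scatter). An ester at this position therefore does not by itself go with the lower number: compound 1 fits that reading, but compound 4 goes against it.

On these data alone, whether a butoxy ester or a carboxylic acid on the same carbonyl carbon would sit with compound 1 or with compound 4 remains open. Nothing measured here gives a cause for the difference between the ethoxy and propoxy esters.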